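This account rests on a few compounds, and the source may have more. Where it says the series, first, only, none or still open, it means among the compounds named here.

Measured compounds:
compound 1, `CN(C)CCCNc1nc(-c2ccc(NC(=O)Nc3ccc(Cl)cc3Cl)cc2)nc2c(Cl)c(Cl)sc12` — 3490 nM
compound 2, `Cc1ccc(NC(=O)Nc2ccc(-c3nc(NCCCN(C)C)c4sc(Cl)c(Cl)c4n3)cc2)cc1` — 4980 nM
compound 3, `CCN(CC)CCNc1nc(-c2ccc(NC(=O)Nc3ccc(Cl)cc3Cl)cc2)nc2c(Cl)c(Cl)sc12` — 1920 nM

All three compounds were tested in a functional assay on MDA-MB-231 cells (Homo sapiens) for cytotoxicity, read by MTT assay, with a stated time of 72 h; a lower number here means a stronger inhibitor, a higher number a weaker inhibitor. Compound 1 and compound 2 share the same core and differ in a single place: 4-methylphenyl in place of 2,4-dichlorophenyl on an amide-type nitrogen. That change gave the step of a 1.4-fold higher number from compound 1 to compound 2 (0.15 log units; within the scatter), so the two numbers cannot be told apart with confidence.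

Compound 3 keeps the aryl urea part of compound 1 but carries a different chain on the core; the difference is diethylamino in place of (dimethylamino)methyl on a saturated chain carbon, two bonds along the chain from a nitrogen on an aromatic ring, and the step is a 1.8-fold lower number from compound 1 to compound 3 (0.26 log units; within the scatter). Compound 3 has the lowest number of the three, and the gap to compound 2 is the only one beyond the scatter. No direct comparison of compound 2 and compound 3 is broken down here; their two values are simply what they are.

Compound 4, `CCN(CC)CCNc1nc(-c2ccc(NC(=O)Nc3ccc(C)cc3)cc2)nc2c(Cl)c(Cl)sc12`, has not yet been measured. It differs from compound 3 by 4-methylphenyl in place of 2,4-dichlorophenyl on an amide-type nitrogen. This is the same change as that from compound 1 to compound 2, now made on the core of compound 3 rather than the core of compound 1; the place is the same in both cases.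

Among the compounds with values here, the step is expected to be small, a 1.4-fold higher number from compound 3 to compound 4 (0.15 log units; within the scatter), because a 1.4-fold higher number from compound 1 to compound 2 (0.15 log units; within the scatter) is the only evidence for this change and it lay within the scatter. Compound 4 is therefore estimated at about 2700 nM in this assay, expected to fall between 1400 nM and 5500 nM.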

Compound 4, half-maximal inhibitory concentration: 2010 nM
Compound 4: the middle estimate sits 1.3-fold (0.13 log units) above what was measured; the range from low to high includes it.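

In this assay, placing 4-methylphenyl in place of 2,4-dichlorophenyl on the amide-type nitrogen gives a 1.0-fold higher number from compound 3 to compound 4 (0.02 log units; within the scatter), and this small step carries over from one core to the other: the same change on two cores in this assay, a 1.4-fold higher number (0.15 log units; within the scatter) from compound 1 to compound 2 and a 1.0-fold higher number (0.02 log units; within the scatter) from compound 3 to compound 4, 1.4-fold (0.13 log units) apart, within the scatter of two such steps. Within the data shown here, the chain change, diethylamino in place of (dimethylamino)methyl, gives a 2.5-fold lower number from compound 2 to compound 4 (0.39 log units; beyond the scatter), and although only this step lies beyond the scatter, it does not differ from its counterpart on the other core: the same change on two cores in this assay, a 1.8-fold lower number (0.26 log units; within the scatter) from compound 1 to compound 3 and a 2.5-fold lower number (0.39 log units; beyond the scatter) from compound 2 to compound 4, 1.4-fold (0.13 log units) apart, within the scatter of two such steps. Both changes therefore behave alike in the two settings shown, but this rests on just two pairs in one assay, does not show that either change would carry over to a different core, and gives no reason for the size of either step.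

The compounds shown leave open how the numbers would respond to a quite different group on the amide-type nitrogen, such as a methoxyphenyl or a trifluoromethylphenyl. They also leave open what a longer chain, or a cyclic amine such as morpholine in place of diethylamino, would do.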